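Trifluoromethoxy step from compound 1 to compound 4

The source may report more compounds than this note shows. Statements on the series, on what has been measured and on what is new or still open speak of the compounds shown alone.

Values from an ADME assay on BJ cells (Homo sapiens) for cytotoxicity, with a stated time of 72 h (on this read-out higher numbers stand for an effect only at larger amounts of compound and lower numbers for an effect already at smaller amounts), follow, each one a limit and not a number.

- compound 1 `C=C[C@@](C)(/C=C/c1ccc(Nc2ccccc2)cc1)CCC=C(C)C` gives > 36600 nM as a limit
- compound 2 `C=C[C@@](C)(/C=C/c1ccc(Nc2ccc(OC)c(F)c2)cc1)CCC=C(C)C` gives > 36600 nM as a limit
- compound 3 `C=C[C@@](C)(/C=C/c1ccc(Nc2cccc(OC(F)(F)F)c2)cc1)CCC=C(C)C` gives > 36600 nM as a limit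

Compound 1 has no number to start from, and the other two compounds are no different. The whole measured set rests on the limit of > 36600 nM in this assay, at which 3 of the 3 values shown sit, and nothing more.

Compound 4 `C=C[C@@](C)(/C=C/c1ccc(Nc2ccc(OC(F)(F)F)cc2)cc1)CCC=C(C)C` keeps the core of compound 1 and differs from it thus: trifluoromethoxy in place of hydrogen on an aromatic carbon in words, trifluoromethoxy in place of hydrogen on an aromatic carbon, para to a large group.

Going by the values given here, two measured steps bear on this change. The nearer is a step that the two limits leave unreadable from compound 1 to compound 3 and it is the same exchange of hydrogen for trifluoromethoxy. The other is a step that the two limits leave unreadable from compound 1 to compound 2 and it puts 3-fluoro-4-methoxyphenyl in place of phenyl. Neither has a readable size, so neither gives a direction.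

With a step that the two limits leave unreadable from compound 1 to compound 3 as the closest guide, no step beyond the scatter is expected for compound 4, and no direction is expected either. The estimated step is a step that the limit leaves unreadable from compound 1 to compound 4 and it carries the same uncertainty as the limits behind it. For compound 4 the estimated value is 40000 nM with an expected range of 20000 nM to 70000 nM and a report as a limit is the likely outcome.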

Compound 4, half-maximal effective concentration: > 36600 nM
Compound 4 was reported as a limit (the forecaster's own chance of this, stated with the estimate: 85%); the middle value does not contradict the limit.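

Compound 1 and compound 4 give no readable step in this assay, each value being a limit and not a number, and the series stays at a single reading: the limit of > 36600 nM in this assay, at which 4 of the 4 values shown sit.

The compounds shown leave open whether any of them reaches a half-maximal effect on these cells, and whether trifluoromethoxy in place of hydrogen on an aromatic carbon shifts this read-out at all.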